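Hydroxamic acid stilbenes: trifluoromethyl for methyl step

The source may hold more compounds than are shown below. What is called first, only, known or untested is meant among the compounds shown, and "the series" means these compounds.

Working notes on the series. Compound 1 `Cc1ccc(-c2cc(/C=C/c3ccc(C(=O)NO)cc3)c(F)cn2)cc1` is tested in a functional assay on HCT-116 cells (Homo sapiens) for antiproliferative activity, read by CellTiter-Glo, with a stated time of 72 h; on this read-out higher numbers stand for weaker inhibition and lower numbers for stronger inhibition. In this assay compound 1 gives only a limit, > 10000 nM. Compound 2 `O=C(NO)c1ccc(/C=C/c2cc(-c3ccc(C(F)(F)F)cc3)ncc2F)cc1` carries the change (trifluoromethyl in place of methyl on an aromatic carbon). In this assay compound 2 likewise gives only a limit, > 10000 nM. The step that the two limits leave unreadable from compound 1 to compound 2 is therefore not readable, because both values sit at the limit of > 10000 nM in this assay, at which 3 of the 3 values shown sit.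

Compound 3 `Cc1ccc(-c2cncc(/C=C/c3ccc(C(=O)NO)cc3)c2)cc1` has a different core; the difference between the two cores is not broken down here. In this assay compound 3 again gives only a limit, > 10000 nM.

Compound 4 `O=C(NO)c1ccc(/C=C/c2cncc(-c3ccc(C(F)(F)F)cc3)c2)cc1` is not yet measured and differs from compound 3 by trifluoromethyl in place of methyl on an aromatic carbon, the same change as that from compound 1 to compound 2, at a place described in the same words. The expected step is a step that the limit leaves unreadable from compound 3 to compound 4, which rests on the same change having left a step that the two limits leave unreadable from compound 1 to compound 2 unreadable at the limit of > 10000 nM in this assay, at which 3 of the 3 values shown sit. Compound 4 is estimated at 20000 nM, with an expected range from 7000 nM to 60000 nM, and most likely only a limit will again be reported.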

Compound 4, half-maximal inhibitory concentration: > 10000 nM
Compound 4 ended at the assay's limit (the forecaster's own chance of this, stated with the estimate: 85%); the middle value does not contradict the limit.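

No step can be read from compound 3 to compound 4 in this assay, because both compounds give only a limit and not a number: the limit of > 10000 nM in this assay, at which 4 of the 4 values shown sit.

The compounds shown leave open whether trifluoromethyl in place of methyl, or the difference between the two cores, changes antiproliferative activity at all in this assay.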